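This account rests on a few compounds, and the source may have more. Where it says the series, first, only, none or still open, it means among the compounds named here.

Compound 1, `COc1ccccc1Nc1nc(-c2cccc(F)c2)nc2ccc(F)cc12`: in a functional assay on U-937 cells (Homo sapiens) for cytotoxicity, read by MTT assay, with a stated time of 48 h (on this read-out lower numbers stand for stronger inhibition and higher numbers for weaker inhibition), compound 1 gives > 50000 nM, a limit of the assay.
Compound 2, `Oc1cccc(Nc2nc(-c3cccc(F)c3)nc3ccc(F)cc23)c1`: in this assay compound 2 gives > 50000 nM, likewise a limit.
Compound 3, `Oc1ccccc1Nc1nc(-c2cccc(F)c2)nc2ccc(F)cc12`: in this assay compound 3 gives 46300 nM.

Compound 1 thus stands only at a limit, and the limit of > 50000 nM in this assay, at which 2 of the 3 values shown sit, shows where most of this small set sits. Compound 4, `Nc1ccccc1Nc1nc(-c2cccc(F)c2)nc2ccc(F)cc12`, differs from compound 1 by amino in place of methoxy on an aromatic carbon. The closest measured change touches the same oxygen-bearing group: an at least 1.0-fold lower number from compound 1 to compound 3 (0.03 log units; that floor lies within the scatter), a step that stays within the scatter, and an at least 1.0-fold lower number from compound 2 to compound 3 (0.03 log units; that floor lies within the scatter) is no larger. With every measured step within the scatter, no shift beyond it is expected for compound 4. The step expected for compound 4 is a number no higher from compound 1 to compound 4 (the limit leaves the size open). In this assay compound 4 is estimated at 50000 nM, within 25000 nM to 100000 nM.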

Compound 4, half-maximal inhibitory concentration: 47300 nM
Estimate against measurement, compound 4: 1.1-fold (0.02 log units) above; low and high end bracket the measured number.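

Amino on this aromatic carbon, ortho to a large group, adds a nitrogen to the oxygen-bearing groups already compared there, and it gives an at least 1.0-fold lower number from compound 1 to compound 4 (0.02 log units; that floor lies within the scatter). Against hydroxy at the same place it gives a 1.0-fold higher number from compound 3 to compound 4 (0.01 log units; within the scatter), and against the 3-hydroxyphenyl of compound 2 the 2-aminophenyl gives an at least 1.0-fold lower number from compound 2 to compound 4 (0.02 log units; that floor lies within the scatter). No step at this position in this assay yet leaves the scatter, and the set stays at one edge of the read-out: the limit of > 50000 nM in this assay, at which 2 of the 4 values shown sit.

Going by these compounds, whether a carboxylic acid or a dimethylamino group at this place would move the number beyond the scatter stays open. So does the effect of any change elsewhere on the shared core.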